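This account rests on a few compounds, and the source may have more. Where it says the series, first, only, none or still open, it means among the compounds named here.

Compound 3 `COc1ccc2c(=O)c(/C=C/C(=O)Nc3ccccc3C)coc2c1` gives 26900 nM in a functional assay on Huh-7 cells (Homo sapiens) for inhibition, read by MTT assay, with a stated time of 48 h (on this read-out higher numbers stand for weaker inhibition and lower numbers for stronger inhibition), the highest of the three numbers: compound 1 `COc1ccc2c(=O)c(/C=C/C(=O)NCc3ccccc3)coc2c1` gives 13600 nM and compound 2 `COc1ccc2c(=O)c(/C=C/C(=O)NCc3cccc(F)c3)coc2c1` gives 10100 nM. Against compound 1 the step is a 2.0-fold higher number from compound 1 to compound 3 (0.30 log units; within the scatter); against compound 2 it is a 2.7-fold higher number from compound 2 to compound 3 (0.43 log units; beyond the scatter). Compound 4 `COc1ccc2c(=O)c(/C=C/C(=O)Nc3ccc(F)cc3)coc2c1` differs from compound 3 by 4-fluorophenyl in place of 2-methylphenyl on an amide-type nitrogen. Within the data shown here, no measured step exchanges one aryl group for another on this nitrogen; the nearest guides are a 1.3-fold lower number from compound 1 to compound 2 (0.13 log units; within the scatter), where a fluorine entering an aromatic ring stayed within the scatter, and a 2.0-fold higher number from compound 1 to compound 3 (0.30 log units; within the scatter), which also stayed within the scatter. The expected step is therefore a 1.3-fold lower number from compound 3 to compound 4 (0.13 log units; within the scatter), nothing beyond the scatter in either direction. Compound 4 is estimated at 20000 nM, with a range from 8000 nM to 50000 nM.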

Compound 4, half-maximal inhibitory concentration: 33900 nM
For compound 4 the middle estimate is 1.7-fold (0.23 log units) below the measured one, within the range that was stated.
By their numbers in this assay, from the lowest: compounds 2, 1, 3 and 4 (each within the scatter of the next, the first and the last beyond it).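

Swapping the aryl group on the amide-type nitrogen, with a 1.3-fold higher number from compound 3 to compound 4 (0.10 log units; within the scatter), does not separate 2-methylphenyl from 4-fluorophenyl. Compound 4 now opens a gap beyond the scatter to both benzyl-type amides, with a 2.5-fold higher number from compound 1 to compound 4 (0.40 log units; beyond the scatter) and a 3.4-fold higher number from compound 2 to compound 4 (0.53 log units; beyond the scatter), so an aryl group set directly on this nitrogen can give weaker inhibition than a benzyl group. Compound 3 only partly fits this pattern, since its step from compound 1 stays within the scatter.

The compounds shown leave open how a phenethyl chain or a pyridyl ring on this nitrogen would compare. Nothing available accounts for the gap between the aryl and benzyl amides.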